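A few compounds are considered here, and "the series" means these few. Any claim that something is new, unique, unknown or untested is made for them only; others in the source may bear on it.

Working notes on the series. In an assay on isolated protein for inhibition of vascular endothelial growth factor receptor 1 (Homo sapiens), read by ELISA, with a stated time of 20 min, tested at 1 uM (on this read-out lower numbers stand for less inhibition and higher numbers for more inhibition at the one concentration tested (going by the name of the read-out)), compound 3 `CC1(C)OB(c2ccc3ncnc(Nc4ccc(F)c(Cl)c4)c3c2)OC1(C)C` gives 8%, the only figure in the set. For the measured compounds named here, compound 1 `COc1cc2ncnc(Nc3cccc(Cl)c3)c2cc1B1OC(C)(C)C(C)(C)O1` is recorded in this assay as "not active" (no number reported), and compound 2 `COc1cc2ncnc(Nc3ccc(F)c(Cl)c3)c2cc1B(O)O` is recorded in this assay as "not active" (no number reported); neither entry carries a number, so no step between measured compounds can be drawn. Compound 4 `COc1cc2ncnc(Nc3ccc(F)c(Cl)c3)c2cc1B1OC(C)(C)C(C)(C)O1` remains to be measured in this assay. Relative to compound 3 the change is methoxy in place of hydrogen on an aromatic carbon. Compound 1 and compound 2 both return without a number, and compound 3 sits low at 8%. The step of a number 3 percentage points lower from compound 3 to compound 4 (within the scatter) is expected to be none beyond the scatter. For compound 4 the estimate is 5%, with a range from -10% to 20%.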

Compound 4, a percentage reported as inhibition, at one concentration (the size of the read-out at that concentration, not a potency): "not active" (no number reported)
Nothing numeric was reported for compound 4; there is nothing to compare the estimate with.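

For the compounds shown here, compound 4 carries no number in this assay, so no step from compound 3 to compound 4 can be read. No measured evidence bears on this result. The compounds shown leave open whether methoxy in place of hydrogen alters inhibition at all.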